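The source may hold more compounds than are shown below. What is called first, only, known or untested is meant among the compounds shown, and "the series" means these compounds.

Measured so far:
Compound 1 `C=CC(=O)Nc1cc(Nc2nc3c(c(-c4cn(C)c5ccccc45)n2)CSCC3)c(OC)cc1N(C)CCN(C)C`: 506 nM
Compound 2 `C=C(Cl)C(=O)Nc1cc(Nc2nc3c(c(-c4cn(C)c5ccccc45)n2)CSCC3)c(OC)cc1N(C)CCN(C)C`: 716 nM

Both values come from a functional assay on A549 cells (Homo sapiens) for inhibition, read by MTT assay, with a stated time of 72 h (a higher number here means a weaker inhibitor, a lower number a stronger inhibitor), and compound 2 stands level with compound 1 within the scatter. Compound 3 `COc1cc(N(C)CCN(C)C)c(NC(=O)C=C(C)C)cc1Nc1nc2c(c(-c3cn(C)c4ccccc34)n1)CSCC2` carries 2-methylprop-1-en-1-yl in place of 1-chloroethenyl on a carbonyl carbon, with 2-methylprop-1-en-1-yl in place of 1-chloroethenyl on a carbonyl carbon. Among the measured compounds shown here, the only measured step at this carbonyl substituent is a 1.4-fold higher number from compound 1 to compound 2 (0.15 log units; within the scatter), with chloro in place of hydrogen. For the measured compounds named here, no measured compound tests the entering group directly, so the evidence is thin. A small move to a higher number is expected, probably not beyond the scatter. The expected change is a 1.3-fold higher number from compound 2 to compound 3 (0.10 log units; within the scatter). For compound 3 the estimated value is 900 nM, within an expected range of 350 nM to 2500 nM.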

Compound 3, half-maximal inhibitory concentration: 583 nM
For compound 3 the middle estimate is 1.5-fold (0.19 log units) above the measured one; the range from low to high includes it.
By their numbers in this assay, from the lowest: compounds 1, 3 and 2 (each within the scatter of the next).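

In this assay, 2-methylprop-1-en-1-yl on the carbonyl carbon gives a 1.2-fold lower number from compound 2 to compound 3 (0.09 log units; within the scatter) and a 1.2-fold higher number from compound 1 to compound 3 (0.06 log units; within the scatter), so this group reads level with both 1-chloroethenyl and vinyl. At this position, the three groups shown therefore cannot be separated by this read-out. Nothing measured here bears on why these values stand level.

Open, on these data alone, is whether a chain ending in a dimethylamino group, or a saturated ethyl group, on the same carbonyl carbon would also stay level. The compounds shown also leave open whether any group at this position can move the number beyond the scatter.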